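Benzyl for Cyclohexyl on the Ring Nitrogen: Compound 4

A few compounds are considered here, and "the series" means these few. Any claim that something is new, unique, unknown or untested is made for them only; others in the source may bear on it.

Compound 1 `O=Cc1ccc(-c2cn3ccnc3c(-c3ccc4ncn(C5CCCCC5)c4c3)n2)cc1` — 37.1%
Compound 2 `Fc1ccc(-c2cn3ccnc3c(-c3ccc4ncn(C5CCCCC5)c4c3)n2)cc1` — 31%
Compound 3 `c1cn2cc(-c3ccsc3)nc(-c3ccc4ncn(C5CCCCC5)c4c3)c2n1` — 18.4%

In a functional assay on UACC-62 cells (Homo sapiens) for inhibition, read by sulforhodamine B assay, with a stated time of 48 h, tested at 10 uM (a higher number here means more inhibition at the concentration tested (going by the name of the read-out), a lower number less inhibition), compound 1 holds the highest of the three numbers. Compound 2 sits within the scatter of it, as a number 6.1 percentage points lower from compound 1 to compound 2 (within the scatter) shows, while compound 3 lies further off, a number 18.7 percentage points lower from compound 1 to compound 3 (beyond the scatter), and also below compound 2, a number 12.6 percentage points lower from compound 2 to compound 3 (beyond the scatter). Compound 4 `O=Cc1ccc(-c2cn3ccnc3c(-c3ccc4ncn(Cc5ccccc5)c4c3)n2)cc1` differs from compound 1 by benzyl in place of cyclohexyl on an aromatic nitrogen. Every measured step swaps the aryl group on the other side of the shared core; none alters the group on the ring nitrogen, so none bears directly on this change. Compound 4 is therefore expected to stay near compound 1, and the expected step is a number 2.1 percentage points lower from compound 1 to compound 4 (within the scatter), of uncertain direction. The estimate for compound 4 is 35%, between 15% and 55%.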

Compound 4, a percentage reported as inhibition, at one concentration (the size of the read-out at that concentration, not a potency): 37.1%
Compound 4: middle estimate off by 2.1 percentage points, on the low side; measured number inside the range.
By their numbers in this assay, from the lowest: compound 3; then compounds 2, 1 and 4 (each within the scatter of the next).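

In this assay, going by these compounds alone, the group on the ring nitrogen changes for the first time, and benzyl in place of cyclohexyl gives no change at the digits printed from compound 1 to compound 4 (within the scatter). With the 4-formylphenyl group held constant, this nitrogen therefore carries either a non-aromatic or an aromatic six-membered ring with no change beyond the scatter. Nothing measured here explains this result. Still open, on these data alone, is how a methyl group, a phenethyl chain or a chain ending in an amine would fare on this nitrogen. Also open, as far as these compounds go, is whether benzyl would give the same outcome alongside 4-fluorophenyl or thiophen-3-yl.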